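A few compounds are considered here, and "the series" means these few. Any claim that something is new, unique, unknown or untested is made for them only; others in the source may bear on it.

Measured so far in a functional assay on HT-1080 cells (Homo sapiens) for antiproliferative activity, read by sulforhodamine B assay, with a stated time of 48 h; on this read-out higher numbers stand for weaker inhibition and lower numbers for stronger inhibition:
- compound 1 `Nc1ccc(S(=O)(=O)Nc2ccnc3cc(C(F)(F)F)ccc23)cc1`: 29600 nM
- compound 2 `N=C(N)NS(=O)(=O)c1ccc(N/C(S)=N\c2ccnc3cc(C(F)(F)F)ccc23)cc1`: 24300 nM

Compound 2 carries the lower of the two numbers in this assay, but its gap to compound 1 lies within the scatter of repeated measurements, so the two read as equivalent; both sit in the weakly active range. Among the measured compounds shown here, no single-point step between measured compounds is available in this set, and the two compounds differ at more than one place, so nothing about the size of any one change can be taken from them.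

Compound 3 `Cc1noc(NS(=O)(=O)c2ccc(N/C(S)=N\c3ccnc4cc(C(F)(F)F)ccc34)cc2)c1C` is the next member. Relative to compound 2 it differs in one place: a group of 7 heavy atoms (5 carbon, 1 nitrogen, 1 oxygen; one five-membered aromatic ring with 2 hetero atoms) in place of a group of 3 heavy atoms (1 carbon, 2 nitrogen; no ring), on a sulfonamide nitrogen. With no measured step of this kind in the series, the expectation for compound 3 rests only on the level of compound 2, and a shift not far beyond the scatter, if anything towards a lower number, is expected. Compound 3 is therefore estimated at 15000 nM, with a range of 4000 nM to 50000 nM, which corresponds to an expected step of a 1.6-fold lower number from compound 2 to compound 3 (0.21 log units; within the scatter).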

Compound 3, half-maximal inhibitory concentration: 27700 nM
Estimate against measurement, compound 3: 1.8-fold (0.27 log units) below; the range from low to high includes it.
By their numbers in this assay, from the lowest: compounds 2, 3 and 1 (each within the scatter of the next).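

In this assay, among the compounds shown here, 3,4-dimethyl-1,2-oxazol-5-yl in place of the group of 3 heavy atoms on the sulfonamide nitrogen gives a 1.1-fold higher number from compound 2 to compound 3 (0.06 log units; within the scatter) and so provides the first one-place step. At this position, a group with one five-membered aromatic ring, 0 hydrogen-bond donors and 2 hydrogen-bond acceptors reads the same as a group with no ring, 2 hydrogen-bond donors and 1 hydrogen-bond acceptor, and the difference of 7 against 3 heavy atoms leaves the read-out within the scatter. No measurement of any property of these two groups is available to bear on this result.

On these data alone, whether a methyl group, an acetyl group or a phenyl ring on this sulfonamide nitrogen would read apart from these two groups remains open, as does whether any group here can move the value beyond the scatter. Steps involving compound 1 cannot be read, as it differs from each of the other two compounds in more than one place.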